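The compounds below may be only part of what the source reports. "The series", "measured", "known", "first", "only" and "open" are said of these compounds alone.

Compound 1, `O=C(NCCCCc1ccccc1)n1cc(-c2ccccc2)oc1=O`, carries a phenethyl chain on the amide-type nitrogen. In a physicochemical assay for solubility, read by HPLC, in phosphate buffer, measured as kinetic solubility, with a stated time of 1 h, at pH 7.4, tested at 250 uM (a lower number here means a less soluble compound, a higher number a more soluble compound), compound 1 gives < 1000 nM, which is a limit of the measurement rather than a number (the limit of < 1000 nM in this assay, at which 1 of the 2 values shown sits). Compound 2, `CCOCCNC(=O)n1cc(-c2ccccc2)oc1=O`, has ethoxy in place of phenethyl on a saturated chain carbon, two bonds along the chain from an amide-type nitrogen, and in this assay compound 2 gives 20000 nM. Among the measured compounds shown here, that step, an at least 20-fold higher number from compound 1 to compound 2 (1.30 log units; beyond the scatter), is the only measured change here. Compound 3, `O=C(NCCCCc1ccccc1)n1cc(-c2ccc(F)cc2)oc1=O`, differs from compound 1 as follows: fluoro in place of hydrogen on an aromatic carbon. For the measured compounds named here, no measured step touches the phenyl ring of the core, so the phenethyl-to-ethoxy step does not bear directly on this change; it shows only that the chain moved the number, while the fluoro change leaves the chain untouched. Compound 3 is therefore expected to stay near the limit, with a step that the limit leaves unreadable from compound 1 to compound 3 expected within the scatter, giving an estimated 700 nM with a range from 200 nM to 2000 nM.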

Compound 3, solubility: < 1000 nM
Compound 3: a limit, no number; the forecaster's own chance of this, stated with the estimate: 75%; the middle value lies beyond the limit too.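

Compound 1 and compound 3 both give a limit of the measurement rather than a number, so no step can be read between them: the limit of < 1000 nM in this assay, at which 2 of the 3 values shown sit. The compounds shown leave open whether going from phenyl to 4-fluorophenyl moves the number in this assay at all.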